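The source may report more compounds than this note shows. Statements on the series, on what has been measured and on what is new or still open speak of the compounds shown alone.

In a functional assay on MCF-10A cells (Homo sapiens) for antiproliferative activity, with a stated time of 48 h (on this read-out lower numbers stand for an effect already at smaller amounts and higher numbers for an effect only at larger amounts of compound), the series reads as follows:
- compound 1 `COc1ccc2nc(C)cc(SCc3ccc(F)cc3)c2c1` gives 41000 nM
- compound 2 `COc1ccc2nc(C)cc(NCc3ccc(C)cc3)c2c1` gives 18800 nM
- compound 3 `COc1ccc2nc(C)cc(NCc3ccc(C(C)(C)C)cc3)c2c1` gives 6900 nM

Compound 2 with 18800 nM is the second highest of the three numbers, under compound 1 and over compound 3. Compound 4 `COc1ccc2nc(C)cc(NCc3ccccc3F)c2c1` is still unmeasured. Its change from compound 2 is 2-fluorophenyl in place of 4-methylphenyl on a saturated chain carbon bound to a nitrogen on an aromatic ring and amounts to 2-fluorophenyl in place of 4-methylphenyl on a saturated chain carbon bound to a nitrogen on an aromatic ring. For the measured compounds named here, the one measured step that bears on this is a 2.7-fold lower number from compound 2 to compound 3 (0.44 log units; beyond the scatter) for tert-butyl in place of methyl on an aromatic carbon. That step is modest and involves no fluorine, so no step beyond the scatter is expected in this assay in either direction. The expected change is a 1.2-fold higher number from compound 2 to compound 4 (0.07 log units; within the scatter) and remains small. For compound 4 the estimate is 22000 nM with an expected range of 10000 nM to 45000 nM in this read-out.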

Compound 4, half-maximal effective concentration: 14000 nM
Compound 4: the middle estimate sits 1.6-fold (0.20 log units) above what was measured; the range from low to high includes it.
By their numbers in this assay, from the lowest: compound 3; then compounds 4 and 2 (each within the scatter of the next); then compound 1.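

In this assay, the exchange of 4-methylphenyl for 2-fluorophenyl gives a 1.3-fold lower number from compound 2 to compound 4 (0.13 log units; within the scatter) and so stays within the scatter. At this place on a saturated chain carbon bound to a nitrogen on an aromatic ring, a fluorine-bearing group is therefore tolerated without a step beyond the scatter, unlike the tert-butyl exchange, which gave a 2.7-fold lower number from compound 2 to compound 3 (0.44 log units; beyond the scatter) in the same assay. Nothing available here accounts for the result. Open, on these data alone, is how an amine or a carboxylic acid on the aromatic ring would read in this assay, and whether a longer chain in place of the saturated chain carbon would change the number.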